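The compounds below may be only part of what the source reports. "The series", "measured", "known", "first", "only" and "open" are said of these compounds alone.

Working notes on the series, read in a functional assay on PC-3 cells (Homo sapiens) for inhibition, read by MTT assay, with a stated time of 24 h, tested at 0.1 ug/mL; a higher number here means more inhibition of growth at the concentration tested, a lower number less inhibition of growth. For compound 1 `CC(=O)SCCC(CCCCC(=O)O)SC(C)=O` the entry is "not determined" (no result reported), so it offers no comparison. Going by the values given here, compound 2 `O=C(CCCCC1CCSS1)Nc1cccc(C(F)(F)F)c1` gives 6.27%, the only number available, which leaves it unranked against any other compound, although the figure itself sits near the bottom of the percent scale. Compound 3 `O=C(CCCCC1CCSS1)Nc1ccc([N+](=O)[O-])c(C(F)(F)F)c1` has not yet been measured in this assay. It departs from compound 2 by a single change, nitro in place of hydrogen on an aromatic carbon. The new group stands ortho to a trifluoromethyl group and para to a large group. Among the compounds with values here, the series holds no step between measured compounds, so this change has no precedent here, and the expectation rests only on the structural change and on compound 2 at 6.27%. A small rise, or none beyond the usual scatter, is expected, and the estimated step is a number 2.7 percentage points higher from compound 2 to compound 3 (within the scatter). For compound 3 the expected value is 9%, with an estimated range from 1% to 22%.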

Compound 3, percent growth inhibition at one concentration: 5.37%
The estimate for compound 3 lay 3.6 percentage points above the measured number; the measured number falls inside the stated range.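

In this assay, nitro in place of hydrogen on an aromatic carbon, ortho to a trifluoromethyl group and para to a large group, gives a number 0.9 percentage points lower from compound 2 to compound 3 (within the scatter). As the first step available in the series, it shows that compound 2 and compound 3 cannot be told apart at this position at the single concentration tested, so adding the nitro group here does not separate the pair in this read-out. No supporting measurement bears on this result.

Open, going by these compounds, is whether an amine or a carboxylic acid at the same aromatic carbon would give a step beyond the scatter from compound 2 in this assay, and whether a nitro group would read the same on a ring that lacks the trifluoromethyl group. Also open, on these data alone, is whether a longer chain on the shared core would lift the growth inhibition of compound 2 or compound 3 clear of the scatter, as a single step of this kind says nothing about other parts of the structure.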